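The source may hold more compounds than are shown below. What is called first, only, known or untested is meant among the compounds shown, and "the series" means these compounds.

Of the compounds shown here, three built on one shared core have been tested in an ADME assay on HEL cells (Homo sapiens) for cytotoxicity; a lower number here means that less compound is tolerated, a higher number that more compound is tolerated. Compound 1 `O=C(COc1cccc2ccccc12)N/N=C/c1ccc(O)cc1` gives 20 ug/mL. Compound 2 `C/C(=N\NC(=O)COc1cccc2ccccc12)c1ccc([N+](=O)[O-])cc1` gives 100 ug/mL, and compound 3 `COc1cc(/C=N/NC(=O)COc2cccc3ccccc23)cc(OC)c1O` gives 100 ug/mL. Compound 1 therefore stands lowest of the three numbers, and both of the other values lie beyond the usual scatter above it: the cells tolerate less of compound 1 than of compound 2 or compound 3.

The next compound, compound 4 `O=C(COc1cccc2ccccc12)N/N=C/c1ccc(F)cc1`, has not yet been measured. It differs from compound 1 in a single place: fluoro in place of hydroxy on an aromatic carbon. Going by the values given here, no pair of measured compounds differs in exactly this way, so there is no measured step of this kind to lean on. What the measured numbers do show is that compound 1 sits alone at the low end, while compound 2 and compound 3 share the higher value. On that basis a modest upward step is expected for compound 4 in this assay, a 2.5-fold higher number from compound 1 to compound 4 (0.40 log units; beyond the scatter), with a real chance that the change turns out to be nothing beyond the scatter. Compound 4 is estimated at 50 ug/mL, within a range from 20 ug/mL to 100 ug/mL.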

Compound 4, minimum cytotoxic concentration: 100 ug/mL
Compound 4: the middle estimate sits 2.0-fold (0.30 log units) below what was measured, within the range that was stated.
By their numbers in this assay, from the lowest: compound 1; then compounds 2, 3 and 4 (each within the scatter of the next).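

In this assay, going by these compounds alone, the change from hydroxy to fluoro gives a 5.0-fold higher number from compound 1 to compound 4 (0.70 log units; beyond the scatter) and is the first measured step in this set that alters a single place, so the shared core and everything else stay the same across it. This ties the low number of compound 1 to what sits on this one aromatic carbon, since replacing that single group is enough to carry the number beyond the scatter. The change can be described only in terms of what was counted: the group that leaves has one hydrogen-bond donor and one hydrogen-bond acceptor, and the group that enters has neither, but this single pair cannot show whether that difference matters.

Going by these compounds, it remains open whether an amine, a carboxylic acid or a chlorine atom at the same place would give a number like that of compound 1 or like that of compound 4, and whether the same swap would produce a similar step on a different core. What lies behind the step also stays open, as nothing at hand speaks to its cause.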